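Swapping a fluorobenzoyl for an indole on the piperidine

This account rests on a few compounds, and the source may have more. Where it says the series, first, only, none or still open, it means among the compounds named here.

Of the compounds shown here, two sharing the same core have been measured in an assay on isolated protein for binding affinity to 5-hydroxytryptamine receptor 7 (Homo sapiens); a lower number here means a stronger inhibitor, a higher number a weaker inhibitor. Compound 1 `O=C1c2ccccc2CCCN1CCN1CCC(Oc2ccc(Cl)cc2)CC1` gives 11.8 nM. Compound 2 `O=C(c1ccc(F)cc1)C1CCN(CCN2CCCc3ccccc3C2=O)CC1` gives 1.66 nM, the lowest of the two numbers, and the step of a 7.1-fold lower number from compound 1 to compound 2 (0.85 log units; beyond the scatter) lies beyond the scatter. Compound 3 `O=C1c2ccccc2CCCN1CCN1CCC(c2c[nH]c3ccccc23)CC1` has not been measured. It differs from compound 2 in one place: 1H-indol-3-yl in place of (4-fluorophenyl)carbonyl on a saturated ring carbon. Within the data shown here, no measured step covers this particular exchange; the only step on record, from compound 1 to compound 2, swaps a different pair of groups at the same saturated ring carbon, so it shows that this position tolerates change without telling the direction for an indole. The step to compound 3 is therefore expected to be small, a 3.0-fold higher number from compound 2 to compound 3 (0.48 log units; beyond the scatter), with a slight loss as the more likely outcome. Compound 3 is estimated at 5 nM, within a range from 1 nM to 25 nM.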

Compound 3, inhibition constant: 0.407 nM
The estimate for compound 3 lay 12-fold (1.09 log units) above the measured number; the measured number lies below the stated range.
By their numbers in this assay, from the lowest: compound 3; then compound 2; then compound 1.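

Replacing (4-fluorophenyl)carbonyl with 1H-indol-3-yl at this saturated ring carbon gives a 4.1-fold lower number from compound 2 to compound 3 (0.61 log units; beyond the scatter) in this assay, so a low number here does not depend on the carbonyl, or on having a hydrogen-bond acceptor in this group. The entering group instead has a hydrogen-bond donor and no acceptor, and the wider comparison with the 4-chlorophenoxy compound gives a 29-fold lower number from compound 1 to compound 3 (1.46 log units; beyond the scatter), showing that the choice of group at this one carbon can shift the number substantially. Nothing available here explains why the indole gives the lowest of the three numbers.

Going by these compounds, it remains open whether the indole's ring hydrogen on nitrogen matters. An indole with a methyl group on that nitrogen, or a benzofuran with oxygen in its place, would address this question.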